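This account rests on a few compounds, and the source may have more. Where it says the series, first, only, none or still open, it means among the compounds named here.

Measured compounds in a functional assay on SK-MEL-5 cells (Homo sapiens) for inhibition, read by sulforhodamine B assay, with a stated time of 48 h; on this read-out higher numbers stand for lower toxicity in this test and lower numbers for higher toxicity in this test:
compound 1, `O=C(Nc1cccc(-n2cc(-c3ccncc3)c(-c3ccc(Cl)c(O)c3)n2)c1)Nc1cccc(C(F)(F)F)c1`: 13800 nM
compound 2, `O=C(Nc1cccc(-n2cc(-c3ccncc3)c(-c3ccc(Cl)c(O)c3)n2)c1)Nc1ccc(Cl)c(Cl)c1`: 2350 nM
compound 3, `COc1cc(-c2nn(-c3cccc(NC(=O)Nc4ccc(Cl)c(C(F)(F)F)c4)c3)cc2-c2ccncc2)ccc1Cl`: 10400 nM

Compound 3 stands second highest of the three numbers in this assay. Its nearest neighbour is compound 1, whose number is somewhat higher, a gap within the scatter; the furthest is compound 2, whose number is lower by a margin beyond the scatter.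

Compound 4 is `O=C(Nc1cccc(-n2cc(-c3ccncc3)c(-c3ccc(Cl)c(O)c3)n2)c1)Nc1ccc(Cl)c(C(F)(F)F)c1`. Its difference from compound 3 is hydrogen in place of methyl on an oxygen on an aromatic ring, read one bond further out as methoxy to hydroxy, 4-chloro-3-methoxyphenyl to 4-chloro-3-hydroxyphenyl.

Among the measured compounds shown here, the only measured step, a 5.9-fold lower number from compound 1 to compound 2 (0.77 log units; beyond the scatter), concerns the ring on the amide-type nitrogen and not the oxygen substituent, so it does not bear on this change. Compounds 1 and 2 carry the hydroxy and compound 3 the methoxy, but each also differs in the ring on the amide-type nitrogen, so the two changes are not separated in the measured set. No step beyond the scatter is therefore expected in this assay, in either direction.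

Compound 4 is estimated at 10000 nM, range 4000 nM to 25000 nM, which would be a step of a 1.0-fold lower number from compound 3 to compound 4 (0.02 log units; within the scatter).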

Compound 4, concentration lethal to 50% of the cells: 2130 nM
Compound 4: middle estimate off by 4.7-fold (0.67 log units), on the high side, outside the stated range (below it).
By their numbers in this assay, from the lowest: compounds 4 and 2 (each within the scatter of the next); then compounds 3 and 1 (each within the scatter of the next).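

In this assay, with the ring on the amide-type nitrogen held constant, methoxy to hydroxy on the 4-chloro-3-methoxyphenyl ring gives a 4.9-fold lower number from compound 3 to compound 4 (0.69 log units; beyond the scatter), so this single change moves the number beyond the scatter, toward higher toxicity in this test, and is now separated from changes in the other ring. With the hydroxy held constant, the ring on the amide-type nitrogen gives two different results: trifluoromethyl in place of chloro on an aromatic carbon gives a 1.1-fold lower number from compound 2 to compound 4 (0.04 log units; within the scatter), which stays within the scatter, whereas chloro in place of hydrogen on an aromatic carbon gives a 6.5-fold lower number from compound 1 to compound 4 (0.81 log units; beyond the scatter), which lies beyond it. The compounds shown offer no measurement that explains either shift.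

From the compounds shown here alone, only hydroxy and methoxy are compared on this oxygen-bearing position, so it remains open whether an ethoxy group, or an amine in place of the hydroxy, would follow the number of compound 3 or that of compound 4. Among the compounds shown here, the methoxy appears with only one ring on the amide-type nitrogen, so it also remains open whether the methoxy to hydroxy step carries over to the rings of compound 1 and compound 2.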